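Swapping Trifluoromethyl for Methoxy at an Assay Limit

The source may hold more compounds than are shown below. What is called first, only, known or untested is meant among the compounds shown, and "the series" means these compounds.

In an ADME assay on BJ cells (Homo sapiens) for cytotoxicity, with a stated time of 72 h (a higher number here means that more compound is needed for the effect, a lower number that less compound is needed), compound 1 `CCc1ccc(-c2nc3c(c(C)nn3-c3ccccc3)c(-c3ccccc3F)c2C#N)cc1` gives > 20000 nM, which is a limit of the assay and not a number. Compound 2 `CCc1ccc(-c2nc3c(c(C)nn3-c3ccccc3)c(-c3ccccc3C(F)(F)F)c2C#N)cc1` gives > 20000 nM, again only a limit. The record therefore stands at the limit of > 20000 nM in this assay, at which 2 of the 2 values shown sit, and compound 2 has no exact position.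

The next change is methoxy in place of trifluoromethyl on an aromatic carbon. It puts methoxy in place of trifluoromethyl on an aromatic carbon, ortho to a large group, and gives compound 3 `CCc1ccc(-c2nc3c(c(C)nn3-c3ccccc3)c(-c3ccccc3OC)c2C#N)cc1`.

Within the data shown here, only one measured step bears on this change at the same place: a step that the two limits leave unreadable from compound 1 to compound 2. That step gives no size to carry over, so no shift in either direction beyond the scatter is expected in this assay. The expected result is a number no higher from compound 2 to compound 3 (the limit leaves the size open). For compound 3 the estimate is 20000 nM, with an expected range of 10000 nM to 40000 nM.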

Compound 3, half-maximal effective concentration in the BJ assay: > 20000 nM
Compound 3 ended at the assay's limit; the forecaster's own chance of this, stated with the estimate: 80%; the middle value sits exactly at the limit.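

In the BJ assay compound 1 gives > 20000 nM, which is a limit of the assay and not a number. In the BJ assay compound 2 gives > 20000 nM, which is also a limit of the assay. In the BJ assay compound 3 gives > 20000 nM, which is again a limit of the assay. So no step among compound 1, compound 2 and compound 3 can be read in the BJ assay: the limit of > 20000 nM in the BJ assay, at which 3 of the 3 values shown sit. The compounds shown leave open how far each lies from that limit, and whether any of them differ. In a physicochemical assay for solubility, read by spectrophotometry, in phosphate buffer, with a stated time of 18 h, at pH 7.4 (on this read-out lower numbers stand for lower solubility and higher numbers for higher solubility), compound 2 gives 11000 nM and compound 3 gives 7800 nM. These two values lie within the scatter of each other.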